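The source may hold more compounds than are shown below. What is called first, only, known or untested is meant among the compounds shown, and "the series" means these compounds.

Compound 2 `CCCCCCCCn1cc(COC2(C(F)(F)F)Oc3ccccc3C=C2C(=O)OCC)nn1` carries an octyl chain on an aromatic nitrogen of the shared core. In a functional assay on A549 cells (Homo sapiens) for inhibition, read by MTT assay, with a stated time of 24 h (a lower number here means a stronger inhibitor, a higher number a weaker inhibitor), compound 2 gives > 150000 nM, which is a limit of the assay and not a number. Compound 1 `CCOC(=O)C1=Cc2ccccc2OC1(OCc1cn(-c2cccc(OC)c2)nn1)C(F)(F)F` gives in this assay > 150000 nM, again a limit and not a number. Going by the values given here, the one measured step, a step that the two limits leave unreadable from compound 1 to compound 2, is therefore unreadable in size, and both values sit at the limit of > 150000 nM in this assay, at which 2 of the 2 values shown sit. Compound 3 `CCOC(=O)C1=Cc2ccccc2OC1(OCc1cn(CC(=O)Nc2ccc(OC)cc2)nn1)C(F)(F)F` differs from compound 2 by (4-methoxyphenyl)carbamoyl in place of heptyl on a saturated chain carbon bound to an aromatic nitrogen. Among the compounds with values here, no measured step bears on this change with a readable size. The expected step in this assay is a number no higher from compound 2 to compound 3 (the limit leaves the size open), with a value near the limit most likely. Compound 3 is estimated at 150000 nM in this assay, in a range from 40000 nM to 600000 nM.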

Compound 3, half-maximal inhibitory concentration: 29400 nM
Compound 3: middle estimate off by 5.1-fold (0.71 log units), on the high side, and the stated range ends above it.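

In this assay, the group on the saturated chain carbon bound to an aromatic nitrogen makes a readable difference: (4-methoxyphenyl)carbamoyl in place of heptyl gives an at least 5.1-fold lower number from compound 2 to compound 3 (0.70 log units; beyond the scatter). Set against a 3-methoxyphenyl on the aromatic nitrogen, ((4-methoxyphenyl)carbamoyl)methyl gives an at least 5.1-fold lower number from compound 1 to compound 3 (0.70 log units; beyond the scatter). The earlier step between two limits could not be read, and compound 3 is the only one of the three with a real number, while the other two stay at a limit of the assay: the limit of > 150000 nM in this assay, at which 2 of the 3 values shown sit.

The compounds shown leave open whether the amide or the 4-methoxyphenyl ring within the new group accounts for the lower number. From the compounds shown here alone, whether a plain phenyl amide or a carboxylic acid on the same carbon would give a similar number also remains open.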